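Triazole Series at the Assay Limit: A Methoxy Swap

The compounds below may be only part of what the source reports. "The series", "measured", "known", "first", "only" and "open" are said of these compounds alone.

Compound 3, `COc1cc(-n2ncnc2-c2cccc(F)c2)cc(OC)c1OC`, belongs to a small set of compounds built on the same core. In a functional assay on HeLa cells (Homo sapiens) for antiproliferative activity, read by MTT assay, with a stated time of 72 h (on this read-out lower numbers stand for stronger inhibition and higher numbers for weaker inhibition), compound 3 gives > 10000 nM, which is a limit of the assay and not a number. Compound 1, `COc1ccccc1-c1ncnn1-c1cc(OC)c(OC)c(OC)c1`, gives > 10000 nM in this assay, again a limit. Compound 2, `COc1cc(-n2ncnc2-c2ccc(F)cc2)cc(OC)c1OC`, gives > 10000 nM in this assay, also a limit. The three values sit together at the limit of > 10000 nM in this assay, at which 3 of the 3 values shown sit, so compound 3 cannot be placed higher or lower than its two neighbours.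

The unmeasured compound 4, `COc1ccc(-c2ncnn2-c2cc(OC)c(OC)c(OC)c2)cc1`, differs from compound 3 in one place: 4-methoxyphenyl in place of 3-fluorophenyl on an aromatic carbon. The measured steps that bear on this change are a step that the two limits leave unreadable from compound 1 to compound 3, a step that the two limits leave unreadable from compound 2 to compound 3 and a step that the two limits leave unreadable from compound 1 to compound 2; each joins two limits, so none of them has a readable size. Within the data shown here, replacing 2-methoxyphenyl with 4-fluorophenyl or 3-fluorophenyl brought no compound into the measurable range, and no step shows a direction.

Compound 4 is therefore expected to stay at the limit as well, with an expected step that the limit leaves unreadable from compound 3 to compound 4 that is not beyond the scatter. The estimate for compound 4 in this assay is 20000 nM, within 5000 nM to 100000 nM.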

Compound 4, half-maximal inhibitory concentration: 280 nM
Beside the measured number, compound 4's estimate is 71-fold (1.85 log units) above it; measured number outside the range, below it.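

In this assay, the 4-methoxyphenyl group on this aromatic carbon brings the series into the measurable range, with an at least 35-fold lower number from compound 3 to compound 4 (1.55 log units; beyond the scatter) and with an at least 35-fold lower number from compound 2 to compound 4 (1.55 log units; beyond the scatter) as the swap that keeps the substituent's printed ring number and changes only the group on it. Methoxy alone does not account for the result, since moving from the 2-methoxyphenyl compound gives an at least 35-fold lower number from compound 1 to compound 4 (1.55 log units; beyond the scatter) and so the same group counts differently according to where it stands on the phenyl ring. The steps among compounds 1, 2 and 3 still cannot be read, so the whole contrast rests on compound 4 against three compounds that remain at a limit: the limit of > 10000 nM in this assay, at which 3 of the 4 values shown sit.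

The compounds shown leave open whether 3-methoxyphenyl would also reach the measurable range, and whether the gain survives with a longer chain on the oxygen, as in 4-ethoxyphenyl, or with 4-hydroxyphenyl or 4-aminophenyl in its place. They also give no way to say whether the oxygen itself or the added carbon matters.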